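A few compounds are considered here, and "the series" means these few. Any claim that something is new, unique, unknown or untested is made for them only; others in the source may bear on it.

Working notes on the series. Among the compounds with values here, compound 2 `Cc1cc(NC(=O)Nc2cccc(C(F)(F)F)c2)c2ccccc2n1` is the reference point here: in an ADME assay on Raji cells (Homo sapiens) for cytotoxicity, with a stated time of 72 h (on this read-out higher numbers stand for an effect only at larger amounts of compound and lower numbers for an effect already at smaller amounts), compound 2 gives 10000 nM, which is the only number so far reported in this assay. Compound 1 `Cc1cc(NC(=O)Nc2cccc(C(N)=O)c2)c2ccccc2n1` reports only a limit, > 25000 nM, in this assay. Within the data shown here, the one measured step, an at least 2.5-fold lower number from compound 1 to compound 2 (0.39 log units; beyond the scatter), rests on that limit of > 25000 nM in this assay, at which 1 of the 2 values shown sits, and therefore gives a direction but no firm size.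

Compound 3 `Cc1cc(NC(=O)Nc2cccc(OC(F)(F)F)c2)c2ccccc2n1` is not yet measured. Its change from compound 2 is trifluoromethoxy in place of trifluoromethyl on an aromatic carbon. Among the measured compounds shown here, no measured step bears directly on this change: the step from compound 1 to compound 2 exchanged carbamoyl for trifluoromethyl, whereas here trifluoromethoxy replaces trifluoromethyl, a change of a different kind. With nothing in the measured data to point either way, the expectation for this assay is no step beyond the scatter.

The step of no change at the digits printed from compound 2 to compound 3 (within the scatter) is therefore estimated to stay within the usual scatter. Compound 3 is expected to give about 10000 nM, with a likely range from 4000 nM to 25000 nM in this assay.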

Compound 3, half-maximal effective concentration: 9000 nM
Compound 3: the middle estimate sits 1.1-fold (0.05 log units) above what was measured, within the range that was stated.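

At this position, on an aromatic carbon meta to a large group, this assay does not separate trifluoromethoxy from trifluoromethyl: the change gives a 1.1-fold lower number from compound 2 to compound 3 (0.05 log units; within the scatter). A second group now stands on the same side of the carbamoyl compound, with an at least 2.7-fold lower number from compound 1 to compound 3 (0.44 log units; beyond the scatter), so the direction seen earlier with trifluoromethyl alone also holds for trifluoromethoxy across the three compounds shown. Compound 1 is held only as a limit, so this step, like the earlier one, gives a direction and no firm size: the limit of > 25000 nM in this assay, at which 1 of the 3 values shown sits.

The compounds shown leave open whether other groups at this position, such as an amine, a carboxylic acid or a longer alkyl chain, would stay level with compound 2 and compound 3 or move beyond the scatter, and whether a plain hydrogen there would fall nearer to those two compounds or to compound 1. They also leave open whether trifluoromethoxy and trifluoromethyl would stay equally matched at another carbon of the same ring or on a changed core, and how far carbamoyl truly lies from either group.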